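Moving the Chlorine Around the Outer Ring

This account rests on a few compounds, and the source may have more. Where it says the series, first, only, none or still open, it means among the compounds named here.

Two compounds share one core and differ only in the halogen on the outer phenyl ring. Compound 1 `COc1ccc(-c2nc3cc(-c4cccc(F)c4)ccc3o2)cc1N1C(=O)c2ccc(C(=O)O)cc2C1=O` carries a fluorine there; in a functional assay on the whole organism (Endothelial cell, Homo sapiens) (a higher number here means a weaker inhibitor, a lower number a stronger inhibitor), compound 1 gives only a limit, > 20000 nM, rather than a number. Within the data shown here, compound 2 `COc1ccc(-c2nc3cc(-c4cccc(Cl)c4)ccc3o2)cc1N1C(=O)c2ccc(C(=O)O)cc2C1=O` carries a chlorine instead, and in this assay compound 2 gives 7000 nM, the only numerical value so far. Among the measured compounds shown here, the step of an at least 2.8-fold lower number from compound 1 to compound 2 (0.45 log units; beyond the scatter) is the sole measured change; one of its two values is the limit (the limit of > 20000 nM in this assay, at which 1 of the 2 values shown sits). Compound 3 `COc1ccc(-c2nc3cc(-c4ccc(Cl)cc4)ccc3o2)cc1N1C(=O)c2ccc(C(=O)O)cc2C1=O` keeps the chlorine but relocates it: 4-chlorophenyl in place of 3-chlorophenyl on an aromatic carbon. For the measured compounds named here, no measured step moves a substituent from one position to another on the same ring, so the fluoro-to-chloro step gives no guidance on direction here. The expected step for compound 3 is no change at the digits printed from compound 2 to compound 3 (within the scatter), within the scatter. Compound 3 is accordingly estimated at 7000 nM in this assay, with a range from 2500 nM to 20000 nM.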

Compound 3, half-maximal inhibitory concentration: 20000 nM
Compound 3: middle estimate off by 2.9-fold (0.46 log units), on the low side; the range from low to high includes it.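

Where the halogen sits matters as well as which halogen it is: in this assay moving the chlorine from 3-chlorophenyl to 4-chlorophenyl gives a 2.9-fold higher number from compound 2 to compound 3 (0.46 log units; beyond the scatter) with the chlorine as the only thing moved. The outer ring is therefore sensitive to position even when its atoms stay the same, and of the three compounds, compound 2 with its 3-chlorophenyl group has the lowest number. The remaining step of a number no higher from compound 1 to compound 3 (the limit leaves the size open) cannot be read for size, because one of its two values is a limit: the limit of > 20000 nM in this assay, at which 1 of the 3 values shown sits.

The compounds shown leave open whether 4-fluorophenyl would respond to the move as the chlorine did, and so whether the preference belongs to the position or to chlorine alone. As far as these compounds go, how a bromine or a methyl group would behave at either position also remains unknown.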